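A few compounds are considered here, and "the series" means these few. Any claim that something is new, unique, unknown or untested is made for them only; others in the source may bear on it.

In an ADME assay on HEK293 cells (Homo sapiens) for cytotoxicity, read by reporter gene assay and resazurin assay, with a stated time of 48 h (a higher number here means that more compound is tolerated, a lower number that less compound is tolerated), compound 2 `O=C(Nc1ccc(Sc2nc3ccccc3s2)cc1)c1ccccc1O` gives 74000 nM, level within the scatter with compound 3 `O=C(Nc1ccc(Sc2nc3ccccc3s2)c(Cl)c1)c1ccccc1O` at 64000 nM. Compound 1 `O=C(Nc1ccc(Sc2nc3ccccc3s2)cc1)c1cc(Br)cc(Br)c1` reports only a limit, > 100000 nM.

The next structure, compound 4 `O=C(Nc1ccc(Sc2nc3ccccc3s2)cc1)c1cc(Br)ccc1O`, differs from compound 2 by a single change: bromo in place of hydrogen on an aromatic carbon. This is bromo in place of hydrogen on an aromatic carbon, para to a hydroxy group, turning 2-hydroxyphenyl into 5-bromo-2-hydroxyphenyl.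

Among the measured compounds shown here, two measured steps bear on it. The nearest in kind is chloro in place of hydrogen on an aromatic carbon, although not on the 2-hydroxyphenyl group, and it gave a 1.2-fold lower number from compound 2 to compound 3 (0.06 log units; within the scatter). The other is 2-hydroxyphenyl in place of 3,5-dibromophenyl, which gave an at least 1.3-fold lower number from compound 1 to compound 2 (0.13 log units; that floor lies within the scatter), so the bromo groups of compound 1 came with no step beyond the scatter. Neither step leaves the scatter, so no real shift is expected, with a slightly lower number the more likely direction. The expected change is a 1.5-fold lower number from compound 2 to compound 4 (0.17 log units; within the scatter). For compound 4 the estimate is 50000 nM, with an expected range from 20000 nM to 100000 nM.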

Compound 4, half-maximal cytotoxic concentration: 42000 nM
Compound 4: middle estimate off by 1.2-fold (0.08 log units), on the high side; low and high end bracket the measured number.
By their numbers in this assay, from the lowest: compounds 4, 3 and 2 (each within the scatter of the next). At a limit, above all of these: compound 1.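

Bromo in place of hydrogen, para to a hydroxy group on the 2-hydroxyphenyl group, gives a 1.8-fold lower number from compound 2 to compound 4 (0.25 log units; within the scatter) in this assay, so a halogen on this ring produces no shift beyond the scatter, as the chloro step on the other aromatic ring also did not. Replacing 3,5-dibromophenyl with 5-bromo-2-hydroxyphenyl gives an at least 2.3-fold lower number from compound 1 to compound 4 (0.37 log units; beyond the scatter), the only step among those shown that lies beyond the scatter. Compound 1 gives a limit, > 100000 nM, so this step is a floor and not a measured size: the limit of > 100000 nM in this assay, at which 1 of the 4 values shown sits.

From the compounds shown here alone, what an amine, a methoxy group or a carboxylic acid would do at this same place in this assay remains open. Also open, going by these compounds, is whether bromo elsewhere on the 2-hydroxyphenyl group would stay within the scatter as well.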